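The compounds below may be only part of what the source reports. "The series", "measured", "known", "first", "only" and "open" are said of these compounds alone.

Working notes on the series. Compound 1 `CCCc1cc(Cn2c(CC)nc3c(C)cc(C)nc32)cc(CCC)c1OC(C(=O)O)c1cccc(-c2ccccc2)c1` carries a 3-phenylphenyl group on the chain carbon next to the acid; in an assay on isolated protein for displacement of a labelled ligand from Type-2 angiotensin II receptor (Rattus norvegicus) (a higher number here means a weaker inhibitor, a lower number a stronger inhibitor), compound 1 gives 740 nM. Compound 2 `CCCc1cc(Cn2c(CC)nc3c(C)cc(C)nc32)cc(CCC)c1OC(C(=O)O)c1ccccc1Cl` has 2-chlorophenyl at that position, and in this assay compound 2 gives 3500 nM. Compound 3 `CCCc1cc(Cn2c(CC)nc3c(C)cc(C)nc32)cc(CCC)c1OC(C(=O)O)c1ccccc1` carries unsubstituted phenyl; in this assay compound 3 gives 2600 nM, the second highest of the three numbers, with a 1.3-fold lower number from compound 2 to compound 3 (0.13 log units; within the scatter) and a 3.5-fold higher number from compound 1 to compound 3 (0.55 log units; beyond the scatter).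

Compound 4 `CCCc1cc(Cn2c(CC)nc3c(C)cc(C)nc32)cc(CCC)c1OC(C(=O)O)c1cccc(Oc2ccccc2)c1` differs from compound 3 by phenoxy in place of hydrogen on an aromatic carbon. The step that bears on this is the reverse of the phenyl removal, a 3.5-fold higher number from compound 1 to compound 3 (0.55 log units; beyond the scatter), which concerns a ring on the same aromatic carbon; the chloro comparison, a 1.3-fold lower number from compound 2 to compound 3 (0.13 log units; within the scatter), is less relevant and anyway within the scatter. A ring joined through an oxygen rather than directly has not been sampled in this set, so only part of the phenyl effect is assumed to carry over. Compound 4 is therefore expected to show a modest lower number, a 2.6-fold lower number from compound 3 to compound 4 (0.41 log units; beyond the scatter). The estimate for compound 4 is 1000 nM, within 350 nM to 2800 nM.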

Compound 4, half-maximal inhibitory concentration: 1600 nM
Compound 4: middle estimate off by 1.6-fold (0.20 log units), on the low side, within the range that was stated.
By their numbers in this assay, from the lowest: compound 1; then compounds 4, 3 and 2 (each within the scatter of the next, the first and the last beyond it).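

In this assay, the phenoxy group on this aromatic carbon cannot be told apart from hydrogen, with a 1.6-fold lower number from compound 3 to compound 4 (0.21 log units; within the scatter) as the step, so a ring joined through an oxygen gives no change beyond the scatter, unlike the directly joined phenyl of compound 1. The join itself does register: both compounds carry a second ring on that carbon, yet the step is a 2.2-fold higher number from compound 1 to compound 4 (0.33 log units; beyond the scatter) and favours the direct join in compound 1. Nothing at hand accounts for this difference between phenoxy and phenyl.

As far as these compounds go, it remains open whether the second ring must be aromatic, as cyclohexyl would show, and whether other joins, such as the methylene of a benzyl group or an amine, behave like the direct bond or like the oxygen. Substituents on the outer ring, such as a carboxylic acid or an aminomethyl group, are also untested in the compounds shown here.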